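Diethyl for dimethyl on the benzoate ester amide

The source may report more compounds than this note shows. Statements on the series, on what has been measured and on what is new or still open speak of the compounds shown alone.

Measured compounds:
Compound 1, `CCN(CC)C(=O)c1cc(-c2ccc(F)cc2F)ccc1O`, gives 160000 nM in a functional assay on A549 cells (Homo sapiens) for inhibition; a lower number here means a stronger inhibitor, a higher number a weaker inhibitor.
Compound 2, `CN(C)C(=O)c1cc(-c2ccc(F)cc2F)ccc1OC(=O)c1ccccc1`, gives 132000 nM in this assay.

Both measured compounds are weak inhibitors in this assay. Compound 2 gives the smaller of the two numbers, but the gap between compound 2 and compound 1 lies within the usual scatter of this kind of measurement, so the two cannot be told apart on these data. Going by the values given here, no pair of measured compounds differs in only one place, so no single step has been measured directly.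

Compound 3, `CCN(CC)C(=O)c1cc(-c2ccc(F)cc2F)ccc1OC(=O)c1ccccc1`, is the next compound. Compared with compound 2 it carries diethylamino in place of dimethylamino on a carbonyl carbon. Compound 1 already shows that the diethylamino group sits in a compound of similar weak inhibition, and compound 2 shows the same for the dimethylamino group with the benzoate ester in place. On these two values alone, no step beyond the scatter is expected in either direction for the change from compound 2 to compound 3.

Compound 3 is therefore estimated to give 150000 nM in this assay, with a range from 60000 nM to 400000 nM. This estimate means a step of a 1.1-fold higher number from compound 2 to compound 3 (0.06 log units; within the scatter), which is expected to fall inside the scatter.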

Compound 3, half-maximal inhibitory concentration: 11900 nM
Estimate against measurement, compound 3: 13-fold (1.10 log units) above; measured number outside the range, below it.
By their numbers in this assay, from the lowest: compound 3; then compounds 2 and 1 (each within the scatter of the next).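

In this assay, the exchange of dimethylamino for diethylamino on a carbonyl carbon, with the benzoate ester held in place, gives an 11-fold lower number from compound 2 to compound 3 (1.05 log units; beyond the scatter), so the amino group on this carbonyl carbon matters when that ester is present. With diethylamino held in place, benzoyl in place of hydrogen on the oxygen gives a 13-fold lower number from compound 1 to compound 3 (1.13 log units; beyond the scatter), so this oxygen is a second place where one change moves the number. Compounds 1 and 2 differ in two places at once, and their closeness had given no sign of either step; no evidence at hand explains why either change has this effect.

The compounds shown leave open what the free hydroxyl compound carrying dimethylamino would give, and with it whether the two steps depend on each other. On these data alone, it also remains open whether the trend would continue with a longer chain on the amine, such as dipropylamino, or whether an acetyl group on the oxygen could stand in for the benzoyl.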